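Working notes: three measured compounds and one pending analogue

The compounds below may be only part of what the source reports. "The series", "measured", "known", "first", "only" and "open" are said of these compounds alone.

Measured so far, in an assay on isolated protein for inhibition of interferon-induced, double-stranded RNA-activated protein kinase (Homo sapiens), read by luminescence, with a stated time of 10 min; on this read-out higher numbers stand for weaker inhibition and lower numbers for stronger inhibition:
compound 1 `O=C1NCc2c1c1c3ccccc3n3c1c1c2c2ccccc2n1C1CCC3O1`: 750 nM
compound 2 `Cc1[nH]c2ccccc2c1-c1ccnc(NCCO)n1`: 11000 nM
compound 3 `CN1CCN(c2ccc(Nc3ncnc4ccc([N+](=O)[O-])cc34)cc2)CC1`: 15000 nM

Compound 2 gives the second highest of the three numbers in this assay. Compound 3 lies within the scatter of it, so the two are not separable; compound 1 sits beyond the scatter with a markedly lower number.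

Compound 4 `Cc1[nH]c2ccccc2c1-c1ccnc(Nc2ccc(F)cc2)n1` differs from compound 2 in one place: 4-fluorophenyl in place of 2-hydroxyethyl on a nitrogen on an aromatic ring. Going by the values given here, no measured pair shows this change, so its size cannot be read from the present numbers. A step toward a lower number, of moderate size and possibly beyond the scatter, is expected: a 2.8-fold lower number from compound 2 to compound 4 (0.44 log units; beyond the scatter). For compound 4 the estimate is 4000 nM, with a range from 1000 nM to 15000 nM.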

Compound 4, half-maximal inhibitory concentration: 150 nM
Beside the measured number, compound 4's estimate is 27-fold (1.43 log units) above it, and the stated range ends above it.
By their numbers in this assay, from the lowest: compound 4; then compound 1; then compounds 2 and 3 (each within the scatter of the next).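

In this assay, going by these compounds alone, the change to 4-fluorophenyl on a nitrogen on an aromatic ring gives a 73-fold lower number from compound 2 to compound 4 (1.87 log units; beyond the scatter) and so shows that the number responds strongly to the group at this position, which the earlier compounds, with no pair differing in one place, could not show. The step combines the loss of a chain without a ring, with its hydrogen-bond donor and acceptor, and the arrival of a six-membered aromatic ring of carbon only. Nothing available explains the size of this step.

The compounds shown leave open whether the step belongs to the aromatic ring or to the fluorine. Going by these compounds, how a plain phenyl, a benzyl or a 2-aminoethyl group on this nitrogen would read also remains open.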